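The source may report more compounds than this note shows. Statements on the series, on what has been measured and on what is new or still open speak of the compounds shown alone.

In a functional assay on MDBK cells (Bos taurus) for cytotoxicity (on this read-out higher numbers stand for lower toxicity in this test and lower numbers for higher toxicity in this test), compound 2 (`CO/N=C(\C#N)C(=O)NCC1=NOC(C(C)(C)C)C1`) gives > 100 ug/mL, which is a limit of the assay and not a number. Compound 1 (`CO/N=C(\C#N)C(=O)NCC1=NOC(C)(C)C1`) gives > 100 ug/mL, also a limit. Compound 3 (`CO/N=C(/C#N)C(=O)NCC1=NOC(C)(C)C1`) gives > 100 ug/mL, again a limit. Compound 4 (`CO/N=C(/C#N)C(=O)NCC1=NOC(C(C)(C)C)C1`) has not yet been measured, and its change from compound 2 is this: the two compounds have the same atoms and bonds; at least one stereo element is drawn with a configuration in one of them and without one in the other: 1 of 2 stereo elements differ; a double bond is drawn E in compound 2 and Z in compound 4. Only a step that the two limits leave unreadable from compound 1 to compound 3 bears on this change, and it is of the same kind, given (the fact that compounds 1 and 3 differ only in the configuration as drawn). Its size cannot be read because of the limit of > 100 ug/mL in this assay, at which 3 of the 3 values shown sit. Neither configuration of that pair shows a number, so no step beyond the scatter is expected in this assay, and the estimate is a step that the limit leaves unreadable from compound 2 to compound 4. For compound 4 the expected value is 130 ug/mL, with an estimated range from 70 ug/mL to 300 ug/mL.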

Compound 4, half-maximal cytotoxic concentration: > 100 ug/mL
Compound 4: a limit, no number; the forecaster's own chance of this, stated with the estimate: 90%; the middle value lies beyond the limit too.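

Among the compounds shown here, compound 2 and compound 4 each give a limit and not a number in this assay, so no step between them can be read. The compounds shown leave open whether the E or Z configuration of the double bond changes toxicity in this assay at all.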